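This account rests on a few compounds, and the source may have more. Where it says the series, first, only, none or still open, it means among the compounds named here.

Compound 1 `O=c1ncn(Cc2c(F)cc(F)cc2F)c2ccc(Oc3cccc(-c4ccc5[nH]ccc5c4)c3C(F)(F)F)cc12` gives < 0.1 ug/mL in a physicochemical assay for solubility, using the shake flask method, with a stated time of 24 h, at pH 6.8 (a higher number here means a more soluble compound, a lower number a less soluble compound), which is a limit of the assay.
Compound 2 `O=c1ncn(Cc2c(F)cc(F)cc2F)c2ccc(Oc3cccc(-c4ccc5[nH]cnc5c4)c3C(F)(F)F)cc12` gives < 0.1 ug/mL in this assay, again a limit.
Compound 3 `O=c1ncn(Cc2c(F)cc(F)cc2F)c2ccc(Oc3cccc(-c4ccc5cc[nH]c5c4)c3C(F)(F)F)cc12` gives < 0.1 ug/mL in this assay, also a limit.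

Compound 3 therefore stands at the same point as the other two, at the limit of < 0.1 ug/mL in this assay, at which 3 of the 3 values shown sit, and the steps a step that the two limits leave unreadable from compound 1 to compound 3 and a step that the two limits leave unreadable from compound 2 to compound 3 cannot be read. Compound 4 `Nc1ccc(-c2cccc(Oc3ccc4c(c3)c(=O)ncn4Cc3c(F)cc(F)cc3F)c2C(F)(F)F)cn1` carries the change (6-aminopyridin-3-yl in place of 1H-indol-6-yl on an aromatic carbon). Within the data shown here, no measured step bears on this change, as the steps among compounds 1, 2 and 3 all run between limits, so the direction and size of an at least 3.0-fold higher number from compound 3 to compound 4 (0.47 log units; beyond the scatter) are expected only loosely. For compound 4 the estimate in this assay is 0.3 ug/mL, within 0.05 ug/mL to 3 ug/mL, with a fair chance that only a limit is reported.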

Compound 4, solubility: < 0.1 ug/mL
Compound 4: a limit, no number; the forecaster's own chance of this, stated with the estimate: 45%; middle value at least 3.0-fold (0.47 log units) from the limit.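

Compound 4 gives < 0.1 ug/mL in this assay, which is a limit, so its steps from compound 1, compound 2 and compound 3 cannot be read. The compounds shown leave open whether any of these group changes alters the read-out at all.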